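A few compounds are considered here, and "the series" means these few. Any claim that something is new, unique, unknown or untested is made for them only; others in the source may bear on it.

Measured so far:
- compound 1 `CCOC(=O)c1cnn(CC(C)O)c1NC(=O)Nc1ccc(F)cc1`: 0.2 nM
- compound 2 `CCOC(=O)c1cnn(CC(O)CC)c1NC(=O)Nc1cccc2ccccc12`: 9.6 nM

In a functional assay on cells (Neutrophil, Homo sapiens) for inhibition, with a stated time of 10 min (on this read-out lower numbers stand for stronger inhibition and higher numbers for weaker inhibition), compound 1 stands lowest of the two numbers at 0.2 nM, and compound 2 reads 9.6 nM, a gap well beyond the scatter. Among the measured compounds shown here, no pair of measured compounds differing in one place is available, so the series offers no measured step to serve as a guide.

The next compound is compound 3 `CCOC(=O)c1cnn(CC(O)CC)c1NC(=O)Nc1ccc(F)cc1`. Relative to compound 1 the change is methyl in place of hydrogen on a saturated chain carbon, two bonds along the chain from an oxygen on a saturated carbon; the side chain goes from 2-hydroxypropyl to 2-hydroxybutyl.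

For the measured compounds named here, with no measured step to draw on, the expectation in this assay is a small move toward a higher number, meaning weaker inhibition, and no change beyond the scatter remains possible. Compound 1 at 0.2 nM sets the starting point. Going by the values given here, compound 2 at 9.6 nM is the only other reading, and the number for compound 3 is expected to stay under it. The estimated step is a 2.5-fold higher number from compound 1 to compound 3 (0.40 log units; beyond the scatter). The estimate for compound 3 is 0.5 nM, with an expected range of 0.1 nM to 2.5 nM.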

Compound 3, half-maximal inhibitory concentration: 1.9 nM
Compound 3: the middle estimate sits 3.8-fold (0.58 log units) below what was measured, and the stated range covers the measured number.
By their numbers in this assay, from the lowest: compound 1; then compound 3; then compound 2.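

In this assay, among the compounds shown here, going from 2-hydroxypropyl to 2-hydroxybutyl gives a 9.5-fold higher number from compound 1 to compound 3 (0.98 log units; beyond the scatter), the first measured step that differs in one place. It shows that the saturated chain carbon, two bonds along the chain from an oxygen on a saturated carbon, is sensitive to substitution: a single added methyl weakens inhibition beyond the scatter. Even so, the loss is partial, as compound 3 remains a strong inhibitor at 1.9 nM, and no measurement at hand accounts for the size of the step.

On these data alone, with a single step at this position, the shape of the trend remains open: a longer chain such as 2-hydroxypentyl could extend the loss or level it off, and an amine in place of the hydroxyl would test whether that oxygen matters at all. Also open, as far as these compounds go, is whether the added methyl has a similar effect when the other end of the molecule changes, as it does in compound 2.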